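Swapping a carboxyphenyl for a pyridyl on the core

The source may hold more compounds than are shown below. What is called first, only, known or untested is meant among the compounds shown, and "the series" means these compounds.

Compound 1 `COc1ccc(-n2c(=O)n(Cc3cc4cc(Cl)ccc4n3CCCC#N)c3cnccc32)c(C)c1` gives > 50000 nM in an ADME assay on HeLa cells (Homo sapiens) for cytotoxicity, read by ATP content, with a stated time of 3 days (a higher number here means that more compound is tolerated, a lower number that less compound is tolerated), a limit of the assay.
Compound 2 `N#CCCCn1c(Cn2c(=O)n(-c3ccc(C(=O)O)cc3)c3ccncc32)cc2cc(Cl)ccc21` gives > 50000 nM in this assay, again a limit.

Compound 2 therefore stands only at a limit, and the step that the two limits leave unreadable from compound 1 to compound 2 cannot be read. Compound 3 `N#CCCCn1c(Cn2c(=O)n(-c3ccncc3)c3ccncc32)cc2cc(Cl)ccc21` carries pyridin-4-yl in place of 4-carboxyphenyl on an aromatic nitrogen. For the measured compounds named here, since both known values sit at the same limit (the limit of > 50000 nM in this assay, at which 2 of the 2 values shown sit), no measured step gives a size to compare with. The step that the limit leaves unreadable from compound 2 to compound 3 is expected to be none beyond the scatter. Compound 3 is expected at 60000 nM, in a range from 25000 nM to 150000 nM.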

Compound 3, half-maximal cytotoxic concentration: > 50000 nM
Compound 3: a limit, no number; the forecaster's own chance of this, stated with the estimate: 80%; the middle value does not contradict the limit.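

No step among compound 1, compound 2 and compound 3 can be read, as each value is a limit and not a number: the limit of > 50000 nM in this assay, at which 3 of the 3 values shown sit.

Going by these compounds, whether the group on the aromatic nitrogen changes the concentration tolerated in this assay stays open.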